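The compounds below may be only part of what the source reports. "The series", "measured", "known", "first", "only" and "open" are said of these compounds alone.

In a functional assay on CHO cells for agonist activity at Alpha-1B adrenergic receptor (Homo sapiens), read by FLIPR and calcium flux (on this read-out lower numbers stand for an effect already at smaller amounts and higher numbers for an effect only at larger amounts of compound), compound 3 `c1ccc2c(c1)CCC2c1ncc[nH]1` gives only a limit, > 10000 nM. Compound 1 `Cc1c(OCC2=NCCN2)ccc(Cl)c1NS(C)(=O)=O` likewise returns a limit, > 10000 nM. Compound 2 `CS(=O)(=O)Nc1c(Cl)ccc2c1CCCC2c1ncc[nH]1` also stops at a limit, > 10000 nM. All three measured compounds therefore sit at the limit of > 10000 nM in this assay, at which 3 of the 3 values shown sit, and compound 3 stands no differently from the other two in this assay. Compound 4 `c1cc(-c2cn[nH]c2)c2c(c1)C(c1ncc[nH]1)CC2` differs from compound 3 by 1H-pyrazol-4-yl in place of hydrogen on an aromatic carbon. For the measured compounds named here, no step between measured compounds is available to show what such a change does in this assay. The expected step of a number no higher from compound 3 to compound 4 (the limit leaves the size open) is accordingly none beyond the scatter, with compound 4 expected to stay near the limit. Compound 4 is estimated at 10000 nM, within a range from 1500 nM to 50000 nM.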

Compound 4, half-maximal effective concentration: > 10000 nM
Compound 4: a limit, no number (the forecaster's own chance of this, stated with the estimate: 65%); the middle value lies on the limit itself.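

Compound 3 and compound 4 both stop at a limit in this assay, so no step can be read between them: the limit of > 10000 nM in this assay, at which 4 of the 4 values shown sit. The compounds shown leave open what 1H-pyrazol-4-yl in place of hydrogen does in this read-out, and whether any of them has a measurable effect.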